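A few compounds are considered here, and "the series" means these few. Any claim that something is new, unique, unknown or untested is made for them only; others in the source may bear on it.

Measured so far:
compound 1 `COc1ccc2c(c1)OC(c1cc(OC)c(OC)c(OC)c1)C(C(=O)OC(C)C)=C2` — 11800 nM
compound 2 `CCOCC1=Cc2ccc(OC)cc2OC1c1cc(OC)c(OC)c(OC)c1` — 21300 nM

In a functional assay for inhibition of nuclear factor NF-kappa-B complex (Homo sapiens) (a lower number here means a stronger inhibitor, a higher number a weaker inhibitor), compound 2 gives the highest of the two numbers; its nearest neighbour is compound 1, and the step of a 1.8-fold higher number from compound 1 to compound 2 (0.26 log units; within the scatter) lies within the scatter. Compound 3 `CCCC(=O)C1=Cc2ccc(OC)cc2OC1c1cc(OC)c(OC)c(OC)c1` differs from compound 2 by propylcarbonyl in place of ethoxymethyl on a double-bonded ring carbon. Within the data shown here, the only step bearing on it is a 1.8-fold higher number from compound 1 to compound 2 (0.26 log units; within the scatter), which replaced a carbonyl-bearing group with ethoxymethyl and stayed within the scatter; compound 3 returns a carbonyl to that position. No change beyond the scatter is therefore expected in this assay: the step of a 1.4-fold lower number from compound 2 to compound 3 (0.15 log units; within the scatter) is the estimate. Compound 3 is expected at 15000 nM, with a range from 5000 nM to 40000 nM.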

Compound 3, half-maximal inhibitory concentration: 11700 nM
For compound 3 the middle estimate is 1.3-fold (0.11 log units) above the measured one; measured number inside the range.
By their numbers in this assay, from the lowest: compounds 3, 1 and 2 (each within the scatter of the next).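

In this assay, the exchange of ethoxymethyl for propylcarbonyl on the double-bonded ring carbon gives a 1.8-fold lower number from compound 2 to compound 3 (0.26 log units; within the scatter) and so stays within the scatter. Propyl in place of isopropoxy on the carbonyl carbon gives a 1.0-fold lower number from compound 1 to compound 3 (0.00 log units; within the scatter) and shows no readable difference, so the three groups at this position cannot be told apart here. No supporting evidence bears on this result.

From the compounds shown here alone, whether an amine, a carboxylic acid or a longer chain at this position would give a step beyond the scatter stays open.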